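The compounds below may be only part of what the source reports. "The series", "measured", "known", "first", "only" and "open" are said of these compounds alone.

Measured in a functional assay on B16-F10 cells (Mus musculus) for antiproliferative activity, read by MTT assay, with a stated time of 48 h; a lower number here means a stronger inhibitor, a higher number a weaker inhibitor:
- compound 1 `CCCCOc1ccc(C(=O)/C=C/c2c(/C=C/c3ccc(OC)cc3)cc(OC)cc2OC)cc1`: 5.3 ug/mL
- compound 2 `COc1ccc(/C=C/c2cc(OC)cc(OC)c2/C=C/C(=O)c2cccc(Br)c2)cc1`: 5.1 ug/mL
- compound 3 `CCCCCCOc1ccc(C(=O)/C=C/c2c(/C=C/c3ccc(OC)cc3)cc(OC)cc2OC)cc1`: 10.4 ug/mL

Compound 3 has the highest number of the three, but this is a small lead. The nearest gap is a 2.0-fold higher number from compound 1 to compound 3 (0.29 log units; within the scatter), and only compound 2 at 5.1 ug/mL lies just beyond the scatter from compound 3.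

The next compound is compound 4 `COc1ccc(/C=C/c2cc(OC)cc(OC)c2/C=C/C(=O)c2ccc(N)cc2)cc1`, which carries amino in place of hexyloxy on an aromatic carbon. For the measured compounds named here, two measured steps bear on this change. Shortening the chain is seen in a 2.0-fold higher number from compound 1 to compound 3 (0.29 log units; within the scatter), and replacing the whole ring substituent is seen in a 1.0-fold lower number from compound 1 to compound 2 (0.02 log units; within the scatter). Both stay within the scatter, so changes at this end of the molecule have so far moved this assay very little. Going by the values given here, no measured compound carries amino, so this is an extrapolation, and no large step is expected. The expected change is a 1.6-fold lower number from compound 3 to compound 4 (0.20 log units; within the scatter), a modest drift towards the lower numbers. For compound 4 the estimated value is 6.5 ug/mL, with an expected range from 2.5 ug/mL to 15 ug/mL.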

Compound 4, half-maximal inhibitory concentration: 2.8 ug/mL
For compound 4 the middle estimate is 2.3-fold (0.37 log units) above the measured one; the measured number falls inside the stated range.
By their numbers in this assay, from the lowest: compounds 4, 2, 1 and 3 (each within the scatter of the next, the first and the last beyond it).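

For the compounds shown here, replacing the hexyloxy group with amino, on an aromatic carbon para to a large group, gives a 3.7-fold lower number from compound 3 to compound 4 (0.57 log units; beyond the scatter) in this assay, the only step between compounds differing in one place that lies beyond the scatter. The other two steps (a 1.9-fold lower number from compound 1 to compound 4 (0.28 log units; within the scatter) and a 1.8-fold lower number from compound 2 to compound 4 (0.26 log units; within the scatter)) stay within it, so amino cannot be told apart from the butoxy group of compound 1 or the 3-bromophenyl end of compound 2, and the separation holds only against hexyloxy. This end of the molecule therefore accepts a group as small as amino with no loss in this assay.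

Nothing measured here explains the step. As far as these compounds go, whether it reflects losing the long chain or gaining amino stays open, and a hydroxyl or dimethylamino group on the same carbon would help to separate the two.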